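Toward a Dihydropyranyl Sulfone in the Cytotoxicity Series

The source may report more compounds than this note shows. Statements on the series, on what has been measured and on what is new or still open speak of the compounds shown alone.

Three compounds of this series have been examined in an ADME assay on IMR-90 cells (Homo sapiens) for cytotoxicity, read by CellTiter-Blue, with a stated time of 46 h; a higher number here means that more compound is needed for the effect, a lower number that less compound is needed. Compound 1 (`CC1CCN(S(=O)(=O)c2ccc(NC(=O)c3ccc([N+](=O)[O-])o3)cc2)CC1`) gives > 25000 nM, which is a limit of the assay rather than a number. Compound 2 (`CC1(C)CCN(S(=O)(=O)c2ccc(NC(=O)c3ccc([N+](=O)[O-])o3)cc2)CC1`) likewise gives > 25000 nM, again a limit. Compound 3 (`O=C(Nc1ccc(S(=O)(=O)N2CCC(Cl)CC2)cc1)c1ccc([N+](=O)[O-])o1`) gives > 25000 nM, also a limit.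

Compound 2 therefore stands at the limit shared by every measured member: the limit of > 25000 nM in this assay, at which 3 of the 3 values shown sit. The steps among these three, a step that the two limits leave unreadable from compound 1 to compound 2, a step that the two limits leave unreadable from compound 1 to compound 3 and a step that the two limits leave unreadable from compound 2 to compound 3, cannot be read in size, since both ends of each lie at the limit.

Compound 4 (`O=C(Nc1ccc(S(=O)(=O)C2=CCOC=C2)cc1)c1ccc([N+](=O)[O-])o1`) is the next member. It differs from compound 2 as follows: a group of 6 heavy atoms (5 carbon, 1 oxygen; one six-membered non-aromatic ring with 1 hetero atom) in place of a group of 8 heavy atoms (7 carbon, 1 nitrogen; one six-membered non-aromatic ring with 1 hetero atom), on a sulfonyl sulfur. Among the compounds with values here, the measured steps all concern changes on the saturated ring attached to the sulfonyl sulfur, which is the same region altered here, but none of them gave a readable size, so they offer no direction for this step. The only pattern available is that every change so far has left the value at the limit.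

Compound 4 is accordingly expected to give 30000 nM, with a range from 10000 nM to 100000 nM. This estimate means a step that the limit leaves unreadable from compound 2 to compound 4, expected to lie within the scatter.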

Compound 4, half-maximal effective concentration: > 25000 nM
Compound 4 ended at the assay's limit; the forecaster's own chance of this, stated with the estimate: 80%; the middle value lies beyond the limit too.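

Compound 4 sits at the same limit as compound 1, compound 2 and compound 3, so no step from compound 4 to any of these can be read in size: the limit of > 25000 nM in this assay, at which 4 of the 4 values shown sit.

The compounds shown leave open at what concentration any of them would reach the effect in this assay, and whether the groups on the sulfonyl sulfur differ at all.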